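The source may hold more compounds than are shown below. What is called first, only, known or untested is meant among the compounds shown, and "the series" means these compounds.

Compound 1 `Fc1ccc(-c2cn3ccnc3c(-c3ccc4ncn(C5CCCCC5)c4c3)n2)cc1` and compound 2 `CC(=O)c1ccc(-c2cn3ccnc3c(-c3ccc4ncn(C5CCCCC5)c4c3)n2)cc1` share one core and differ only in the group on the outer phenyl. In a functional assay on MOLT-4 cells (Homo sapiens) for inhibition, read by sulforhodamine B assay, with a stated time of 48 h, tested at 10 uM (a higher number here means more inhibition at the concentration tested (going by the name of the read-out), a lower number less inhibition), compound 1 gives 25.2%, and compound 2 gives 14.3%; the step of a number 10.9 percentage points lower from compound 1 to compound 2 (beyond the scatter) came with acetyl in place of fluoro on an aromatic carbon. Compound 2 is thus the lower of the two numbers measured. Compound 3 `Fc1ccccc1-c1cn2ccnc2c(-c2ccc3ncn(C4CCCCC4)c3c2)n1` is still to be measured and differs from compound 2 in this way: 2-fluorophenyl in place of 4-acetylphenyl on an aromatic carbon. Among the measured compounds shown here, the only comparison that bears on it is a number 10.9 percentage points lower from compound 1 to compound 2 (beyond the scatter), which removed fluoro and brought in acetyl; the present change runs the other way, although the fluoro of compound 3 sits at a different place on its phenyl than in compound 1, so the two changes are not exact mirrors. A rise of roughly that size is therefore expected, with wide uncertainty. Compound 3 is expected to give 24%, in the range 10% to 38%, meaning the step of a number 9.7 percentage points higher from compound 2 to compound 3 (within the scatter).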

Compound 3, a percentage reported as inhibition, at one concentration (the size of the read-out at that concentration, not a potency): 22.5%
Compound 3: middle estimate off by 1.5 percentage points, on the high side; the measured number falls inside the stated range.
By their numbers in this assay, from the lowest: compounds 2, 3 and 1 (each within the scatter of the next, the first and the last beyond it).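

The step of a number 2.7 percentage points lower from compound 1 to compound 3 (within the scatter) came with 2-fluorophenyl in place of 4-fluorophenyl, so moving the fluoro around the outer phenyl leaves a difference that repeated measurements could not separate. The step of a number 8.2 percentage points higher from compound 2 to compound 3 (within the scatter) came with 2-fluorophenyl in place of 4-acetylphenyl, so compound 3 cannot be told apart from either compound 1 or compound 2 in this assay, even though those two differ from each other beyond the scatter. Nothing measured here gives a reason for these numbers.

Going by these compounds, it remains open whether an amine or a carboxylic acid on the outer phenyl would shift the reading clear of the scatter. A methoxy group or a longer chain at this place is equally untested among the compounds shown.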